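Amine substituent variation on the cyanoacrylamide series

The source may report more compounds than this note shows. Statements on the series, on what has been measured and on what is new or still open speak of the compounds shown alone.

Compound 2 `CCOc1ccc(NC(=O)/C(C#N)=C(\Nc2ccccc2)SC)cc1` is the reference point. For the measured compounds named here, in a functional assay on CCRF-CEM cells (Homo sapiens) for cytotoxicity, read by resazurin assay, with a stated time of 48 h (a lower number here means a stronger inhibitor, a higher number a weaker inhibitor), compound 2 gives 20300 nM, the highest of the two measured numbers, though its only neighbour stands within the scatter of it. That neighbour, compound 1 `C=CCN/C(SC)=C(/C#N)C(=O)Nc1ccc(OCC)cc1`, gives 18500 nM in the same assay. Going by the values given here, the one measured step, a 1.1-fold higher number from compound 1 to compound 2 (0.04 log units; within the scatter), is phenyl in place of allyl on the amine nitrogen and lies within the scatter.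

Compound 3 `CCOc1ccc(NC(=O)/C(C#N)=C(\NC)SC)cc1` is the next member and differs from compound 2 by methyl in place of phenyl on an amine nitrogen. Among the compounds with values here, the step from compound 2 to compound 3 varies the same amine nitrogen substituent, so the only measured step that bears on it is a 1.1-fold higher number from compound 1 to compound 2 (0.04 log units; within the scatter), which was within the scatter. Within the data shown here, no step in this set has moved the number beyond the scatter, so for this change too no movement beyond the scatter is expected in this assay. The expected step is a 1.0-fold lower number from compound 2 to compound 3 (0.01 log units; within the scatter). For compound 3 the estimate in this assay is 20000 nM, with a range from 8000 nM to 50000 nM.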

Compound 3, half-maximal inhibitory concentration: 9940 nM
Beside the measured number, compound 3's estimate is 2.0-fold (0.30 log units) above it, within the range that was stated.
By their numbers in this assay, from the lowest: compounds 3, 1 and 2 (each within the scatter of the next, the first and the last beyond it).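

For the compounds shown here, at this amine nitrogen the substituent can now shift the number in this assay, since a 2.0-fold lower number from compound 2 to compound 3 (0.31 log units; beyond the scatter) is the first step in the set to pass the scatter, if only modestly, with methyl in place of phenyl taking away the one six-membered aromatic ring of carbon and leaving a single carbon. The allyl compound does not separate from either end, because a 1.9-fold lower number from compound 1 to compound 3 (0.27 log units; within the scatter) stays within the scatter, as does the earlier step from compound 1 to compound 2, so the three substituents give no graded series and only methyl and phenyl can be told apart. Nothing available bears on why methyl and phenyl differ at this nitrogen.

The compounds shown leave open whether the shift follows the loss of the aromatic ring or simply the smaller substituent, a question that a benzyl, cyclohexyl or longer straight alkyl chain on the same nitrogen would address. On these data alone, it is also open whether the number moves further with only hydrogen on this nitrogen, or with a chain carrying a hydroxyl or a carboxylic acid.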